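Swapping the Aryl Amide: Methoxyphenyl to Nitrophenyl

This account rests on a few compounds, and the source may have more. Where it says the series, first, only, none or still open, it means among the compounds named here.

Compound 1 `CN(C(=O)C(C)(C)C)c1ccc2[nH]c(-c3n[nH]c4ccccc34)cc2n1` gives 4990 nM in a functional assay on HL-60 cells (Homo sapiens) for antiproliferative activity, read by MTT assay, with a stated time of 72 h; a lower number here means a stronger inhibitor, a higher number a weaker inhibitor.
Compound 2 `COc1cccc(C(=O)N(C)c2ccc3[nH]c(-c4n[nH]c5ccccc45)cc3n2)c1` gives 1420 nM in this assay.

Compound 2 has the lower of the two numbers: the step of a 3.5-fold lower number from compound 1 to compound 2 (0.55 log units; beyond the scatter) is beyond the scatter. Compound 3 `CN(C(=O)c1ccc([N+](=O)[O-])cc1)c1ccc2[nH]c(-c3n[nH]c4ccccc34)cc2n1` carries 4-nitrophenyl in place of 3-methoxyphenyl on a carbonyl carbon. Among the measured compounds shown here, no measured step exchanges one aryl group for another on that carbonyl carbon, so the only guide is that compound 2 already holds an aryl group there. The change is expected to leave the number roughly where compound 2 stands, within the scatter, as a 1.1-fold higher number from compound 2 to compound 3 (0.02 log units; within the scatter). Compound 3 is therefore estimated at 1500 nM, in the range 600 nM to 4000 nM.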

Compound 3, half-maximal inhibitory concentration: 6800 nM
Compound 3: the middle estimate sits 4.5-fold (0.66 log units) below what was measured; measured number outside the range, above it.
By their numbers in this assay, from the lowest: compound 2; then compounds 1 and 3 (each within the scatter of the next).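

On the carbonyl carbon, one aryl group does not simply stand in for another: in this assay, 4-nitrophenyl in place of 3-methoxyphenyl gives a 4.8-fold higher number from compound 2 to compound 3 (0.68 log units; beyond the scatter) and so loses the gain seen with compound 2. Set against tert-butyl, 4-nitrophenyl gives a 1.4-fold higher number from compound 1 to compound 3 (0.13 log units; within the scatter) and this shows that an aryl group alone does not bring the lower number. No measurement here explains this difference. The compounds shown also leave open whether the methoxy or nitro group matters more than its place on the ring, which 4-methoxyphenyl and 3-nitrophenyl could separate.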